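The source may report more compounds than this note shows. Statements on the series, on what has been measured and on what is new or still open speak of the compounds shown alone.

Measured so far:
compound 1, `CNc1ncnc2c1ncn2Cc1cccc(F)c1` — 7 mg/kg
compound 2, `CC(C)Nc1ncnc2c1ncn2Cc1ccccc1F` — 5.8 mg/kg

In a functional assay on the whole organism with Rattus norvegicus as the target, in the maximal electroshock model (a lower number here means that less compound is needed, a higher number that more compound is needed for the effect), compound 1 gives 7 mg/kg and compound 2 gives 5.8 mg/kg. Compound 2 stands together with compound 1: the gap between their two numbers lies within the usual scatter of this assay, so the two cannot be told apart on what has been measured. They also differ in more than one place, so no single structural step can be read from the pair.

Compound 3, `Nc1ncnc2c1ncn2Cc1ccccc1F`, has not yet been measured in this assay. Against compound 2 the change is hydrogen in place of isopropyl on a nitrogen on an aromatic ring. Among the compounds with values here, no measured pair isolates this change, so the expectation rests on the change alone. A modest step toward a higher dose, roughly at the edge of the scatter, is expected. The expected step from compound 2 to compound 3 is a 1.9-fold higher number from compound 2 to compound 3 (0.28 log units; within the scatter). Compound 3 is expected to give 11 mg/kg in this assay, with a range from 4 mg/kg to 30 mg/kg.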

Compound 3, dose for half-maximal effect: 4.5 mg/kg
Compound 3: the middle estimate sits 2.4-fold (0.39 log units) above what was measured, and the stated range covers the measured number.
By their numbers in this assay, from the lowest: compounds 3, 2 and 1 (each within the scatter of the next).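

In this assay, the change from isopropylamino to amino gives a 1.3-fold lower number from compound 2 to compound 3 (0.11 log units; within the scatter). Within the data shown here, this is the first comparison that isolates one place: on this nitrogen on an aromatic ring, the pair with isopropyl and with hydrogen cannot be told apart, so in this pair the three carbons of the isopropyl are not required to keep the dose in the same range. Nothing measured on these compounds accounts for this result.

Among these compounds, compound 1 differs from compound 2 and from compound 3 in more than one place, so no step to it can be read, and the contribution of its methyl on this nitrogen stays unresolved. On these data alone, how far this tolerance extends is also open, for instance to a longer chain such as n-hexyl or to an acetyl group on the same nitrogen.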